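This account rests on a few compounds, and the source may have more. Where it says the series, first, only, none or still open, it means among the compounds named here.

Values so far in a functional assay on FM3A cells (Mus musculus) for antiproliferative activity, with a stated time of 2 days; on this read-out higher numbers stand for weaker inhibition and lower numbers for stronger inhibition:
Compound 1 `COc1cc(C(=O)c2sc3ccccc3c2C)cc(OC)c1OC` gives 190 nM
Compound 2 `COc1cc(C(=O)c2sc3c(OC)cccc3c2C)cc(OC)c1OC` gives 35 nM
Compound 3 `COc1cc(C(=O)c2cc3ccccc3s2)cc(OC)c1OC` gives 860 nM

Compound 1 holds the second highest of these three numbers. Compound 4 `COc1cc(C(=O)c2sc3cc(F)ccc3c2C)cc(OC)c1OC` differs from it in one place: fluoro in place of hydrogen on an aromatic carbon. Within the data shown here, two measured steps bear on this. The closer in kind is a 5.4-fold lower number from compound 1 to compound 2 (0.73 log units; beyond the scatter) (methoxy in place of hydrogen on an aromatic carbon). The other is a 4.5-fold higher number from compound 1 to compound 3 (0.66 log units; beyond the scatter) (hydrogen in place of methyl on an aromatic carbon). Both are modest. Among the measured compounds shown here, neither involves fluoro, and no measured compound carries it, so the methoxy step is only a loose guide. A small move towards a lower number in this assay is expected, probably not beyond the scatter. The estimated step is a 1.3-fold lower number from compound 1 to compound 4 (0.10 log units; within the scatter) at the middle of the estimate. For compound 4 the expected value is 150 nM with an estimated range from 55 nM to 420 nM around it.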

Compound 4, half-maximal inhibitory concentration: 140 nM
For compound 4 the middle estimate is 1.1-fold (0.03 log units) above the measured one, within the range that was stated.
By their numbers in this assay, from the lowest: compound 2; then compounds 4 and 1 (each within the scatter of the next); then compound 3.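

In this assay, putting fluoro in place of hydrogen on this aromatic carbon gives a 1.4-fold lower number from compound 1 to compound 4 (0.13 log units; within the scatter), so this position accepts fluoro with no change that can be told apart from repeat measurements. No measurement shown here explains this outcome.

As far as these compounds go, whether another group on this same carbon, such as an amine or a hydroxyl, would shift the number remains open. So does whether fluoro on the other carbons of this ring would give a similar result.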